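A few compounds are considered here, and "the series" means these few. Any claim that something is new, unique, unknown or untested is made for them only; others in the source may bear on it.

Working notes on the series, read in a functional assay on MOLT-4 cells (Homo sapiens) for antiproliferative activity, read by cell counting, with a stated time of 2 days; a lower number here means a stronger inhibitor, a higher number a weaker inhibitor. Compound 1 (`COc1ccc(Nc2nc(N)c(C(=O)c3ccc(Cl)cc3)s2)cc1`) gives 13 nM, the lowest of the three numbers at hand. Compound 2 (`COc1ccc(Nc2nc(N)c(C(=O)c3cc(OC)c(OC)c(OC)c3)s2)cc1`) gives 480 nM and compound 3 (`Cc1ccc(Nc2nc(-n3ccnc3C)cs2)cc1`) gives 510 nM. Both stand above compound 1, beyond the scatter, and within the scatter of each other.

The open case is compound 4 (`COc1ccc(Nc2nc(N)c(C(=O)c3ccc([N+](=O)[O-])cc3)s2)cc1`), not yet measured in this assay. It carries nitro in place of chloro on an aromatic carbon of compound 1, para to a large group: nitro in place of chloro on an aromatic carbon.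

Within the data shown here, no measured pair differs in one place, so no step is available to size this change directly. Among the measured compounds shown here, the only guide is the spread of the three values. Starting from the low end of that spread, a single exchange on compound 1 at 13 nM is expected to raise the number, toward a weaker inhibitor. The rise probably exceeds the scatter but is expected to stop short of the level of compound 2 at 480 nM. The estimated step is a 3.8-fold higher number from compound 1 to compound 4 (0.59 log units; beyond the scatter), an expectation only. For compound 4 the expected value is 50 nM, with an estimated range of 12 nM to 250 nM.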

Compound 4, half-maximal inhibitory concentration: 29 nM
Compound 4: middle estimate off by 1.7-fold (0.24 log units), on the high side; measured number inside the range.
By their numbers in this assay, from the lowest: compound 1; then compound 4; then compounds 2 and 3 (each within the scatter of the next).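

The exchange of chloro for nitro on an aromatic carbon para to a large group gives the series its first one-place step: in this assay it is a 2.2-fold higher number from compound 1 to compound 4 (0.35 log units; beyond the scatter), modest but beyond the scatter. This position therefore accepts nitro, with 3 heavy atoms and 2 hydrogen-bond acceptors in place of a single chlorine with none, at the cost of only that modest rise, and compound 4 still gives 29 nM. Nothing at hand accounts for the size of this step, which remains a bare observation from a single pair.

The compounds shown leave open how other groups on this same carbon would read, such as a nitrile, a carboxylic acid or a dimethylamino group, and so whether the small gap between chloro and nitro holds for a wider set of groups or is particular to these two. Among these compounds, also open is whether the same exchange would give a step of similar size on a core carrying different groups elsewhere, since the one pair at hand shares the core of compound 1.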